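Benzylidene series: halogen swap on the pendant phenyl ring

The compounds below may be only part of what the source reports. "The series", "measured", "known", "first", "only" and "open" are said of these compounds alone.

Measured so far:
- compound 1 `C=CCn1c(=O)/c(=C\c2cccc(Cl)c2)[nH]c(=O)/c1=C\c1ccccc1OC`: 5200 nM
- compound 2 `C=CCn1c(=O)/c(=C\c2cccc(F)c2)[nH]c(=O)/c1=C\c1ccccc1OC`: 19700 nM

In a functional assay on A549 cells (Homo sapiens) for cytotoxicity, read by CCK-8 assay, with a stated time of 72 h (a lower number here means a stronger inhibitor, a higher number a weaker inhibitor), compound 1 gives 5200 nM, the lowest of the two numbers in hand. Within the data shown here, compound 2 gives 19700 nM in this assay, and the only single-point step recorded is a 3.8-fold higher number from compound 1 to compound 2 (0.58 log units; beyond the scatter).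

Compound 3 `C=CCn1c(=O)/c(=C\c2ccccc2C(F)(F)F)[nH]c(=O)/c1=C\c1ccccc1OC` has not been measured. Against compound 1 the change is 2-(trifluoromethyl)phenyl in place of 3-chlorophenyl on a double-bonded chain carbon bound to an aromatic carbon. Among the measured compounds shown here, no measured pair covers a trifluoromethyl group or a change of the group's place on the pendant ring, so the only bearing step is the one from compound 1 to compound 2, which shows that the identity of the substituent on that ring can move the number by a modest, beyond-scatter amount in this assay. Direction for compound 3 cannot be read from that step.

The estimate for compound 3 in this assay is therefore centred a little above compound 1, with a wide range, and the expected step is a 1.5-fold higher number from compound 1 to compound 3 (0.19 log units; within the scatter). Compound 3 is expected at 8000 nM, between 2000 nM and 32000 nM.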

Compound 3, half-maximal inhibitory concentration: 7000 nM
Beside the measured number, compound 3's estimate is 1.1-fold (0.06 log units) above it; the measured number falls inside the stated range.
By their numbers in this assay, from the lowest: compounds 1 and 3 (each within the scatter of the next); then compound 2.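

In this assay, the position on a double-bonded chain carbon bound to an aromatic carbon accepts 2-(trifluoromethyl)phenyl, with 10 heavy atoms in place of the 7 of 3-chlorophenyl, and the result is a 1.3-fold higher number from compound 1 to compound 3 (0.13 log units; within the scatter), so compound 1 and compound 3 cannot be ordered. The same group set against 3-fluorophenyl gives a 2.8-fold lower number from compound 2 to compound 3 (0.45 log units; beyond the scatter), which leaves compound 2 as the only one of the three standing apart, with steps beyond the scatter to both others; a high number is therefore not a general outcome of replacing 3-chlorophenyl at this position. No supporting measurement bears on why the numbers fall this way.

The compounds shown leave open what the trifluoromethyl group and its place on the ring each contribute separately, as group and place change together in both new steps. Also open, going by these compounds, is how an amine or a carboxylic acid on this phenyl ring would read in this assay, as the three compounds cover only halogen and trifluoromethyl substituents.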